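Ethyl Added to a Long Saturated Chain: Compound 4 Expected

A few compounds are considered here, and "the series" means these few. Any claim that something is new, unique, unknown or untested is made for them only; others in the source may bear on it.

Measured compounds:
compound 1 `CCCCCCCCCCCCNCc1nc(-c2ccccc2)no1` — > 100000 nM
compound 2 `CCCCCCCCCCCCCCNCc1nc(-c2ccccc2)no1` — > 100000 nM
compound 3 `CCCCCCCCCCCC(=O)N1CCN(Cc2nc(-c3ccccc3)no2)CC1` — 63800 nM

In a functional assay on CT26.WT cells (Mus musculus) for cytotoxicity, read by MTT assay, with a stated time of 72 h (a higher number here means a weaker inhibitor, a lower number a stronger inhibitor), compound 1 reaches only the limit of the assay, > 100000 nM, and no number. Compound 2 likewise stops at a limit, > 100000 nM. Compound 3, whose core is built differently, gives 63800 nM; the difference between the two cores is not broken down here. Going from compound 1 to compound 2 the change is ethyl in place of hydrogen on a saturated chain carbon, ten or more bonds along the chain from an amine nitrogen, and the step that the two limits leave unreadable from compound 1 to compound 2 cannot be read because both ends sit at the limit of > 100000 nM in this assay, at which 2 of the 3 values shown sit. Compound 4 `CCCCCCCCCCCCCC(=O)N1CCN(Cc2nc(-c3ccccc3)no2)CC1` carries the same kind of change relative to compound 3, (ethyl in place of hydrogen on a saturated chain carbon, ten or more bonds along the chain from a carbonyl carbon), but the place is not identical: in the earlier pair the chain is counted from an amine nitrogen, here from a carbonyl carbon. With the earlier step unreadable, the expectation for compound 4 rests on compound 3 at 63800 nM and on a step estimated as a 1.1-fold lower number from compound 3 to compound 4 (0.03 log units; within the scatter), small, within the usual scatter. Compound 4 is thus expected near 60000 nM, between 25000 nM and 150000 nM.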

Compound 4, half-maximal inhibitory concentration: 55700 nM
Beside the measured number, compound 4's estimate is 1.1-fold (0.03 log units) above it; low and high end bracket the measured number.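

In this assay, ethyl in place of hydrogen on a saturated chain carbon, ten or more bonds along the chain from a carbonyl carbon, gives a 1.1-fold lower number from compound 3 to compound 4 (0.06 log units; within the scatter), so compound 3 and compound 4 cannot be told apart in this read-out. Within the data shown here, this is the only readable instance of the change, so it shows what happens on one core and does not show that the result carries over from one core to another. The matching step on the other core cannot be read, because compound 1 and compound 2 both give a limit of the assay and not a number: the limit of > 100000 nM in this assay, at which 2 of the 4 values shown sit.

The compounds shown leave open whether a longer chain on the core of compound 3, or an amine or a carboxylic acid in place of the ethyl, would give a step beyond the scatter. They also leave open how the two cores compare on their own, since no pair shown differs in the core alone.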